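The source may hold more compounds than are shown below. What is called first, only, known or untested is meant among the compounds shown, and "the series" means these compounds.

Working notes on the series. Among the measured compounds shown here, in a physicochemical assay for lipophilicity, in phosphate buffer, measured as octanol-water partition, with a stated time of 24 h (a lower number here means a more polar compound, a higher number a more lipophilic compound), compound 1 `Fc1ccc(Oc2ccc(/C=N/NC(=S)Nc3ccc(Br)cc3)cc2)cc1` gives 5.82, the lowest of the three numbers measured so far. Compound 2 `Cc1cc(Oc2ccc(/C=N/NC(=S)Nc3ccc(Br)cc3)cc2)ccc1Cl` gives 7.89 in this assay, and compound 3 `S=C(N/N=C/c1ccc(Oc2ccc(Br)cc2)cc1)Nc1ccc(Br)cc1` gives 6.53. The measured steps are a number 2.07 log units higher from compound 1 to compound 2 (beyond the scatter), a number 0.71 log units higher from compound 1 to compound 3 (beyond the scatter) and a number 1.36 log units lower from compound 2 to compound 3 (beyond the scatter). Compound 4 `Fc1ccc(Oc2ccc(/C=N/NC(=S)Nc3ccccc3)cc2)cc1` differs from compound 1 by hydrogen in place of bromo on an aromatic carbon; cut one bond further out, this reads (4-bromophenyl)amino to anilino. Of the measured steps only a number 0.71 log units higher from compound 1 to compound 3 (beyond the scatter) bears on this change, and it was modest in size. Removing the bromo altogether is therefore expected to give a modest step downward in this assay, beyond the scatter. For compound 4 the expected value is 5, within 4.3 to 5.7. This corresponds to an expected step of a number 0.82 log units lower from compound 1 to compound 4 (beyond the scatter).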

Compound 4, partition coefficient: 5.09
For compound 4 the middle estimate is 0.09 log units below the measured one, within the range that was stated.
By their numbers in this assay, from the lowest: compound 4; then compound 1; then compound 3; then compound 2.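

In this assay, among the compounds shown here, the step of a number 0.73 log units lower from compound 1 to compound 4 (beyond the scatter) is the first measured at the (4-bromophenyl)amino end of the series, where hydrogen enters in place of bromo on an aromatic carbon, para to a large group. The read-out therefore responds to a change at this position, not only to changes in the aryl group on the oxygen. Nothing at hand gives a reason for this step. The compounds shown leave open how other groups at this position, such as an amine or a carboxylic acid, would read.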